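Adding a Methylsulfanylethyl Side Chain to Compound 2

A few compounds are considered here, and "the series" means these few. Any claim that something is new, unique, unknown or untested is made for them only; others in the source may bear on it.

Three compounds have so far been measured in a functional assay on the whole organism (Tail, strain ICR) with Mus musculus as the target, in the tail flick test, with a stated time of 30 min, at a dose of 25 umol/kg by the oral route; a lower number here means a weaker effect, a higher number a stronger effect of the compound at the dose given:

compound 1 `O=C(CN(c1nc(Cl)nc2[nH]cnc12)C1CC1)NCC(=O)OCc1ccccc1` gives 18.7%
compound 2 `O=C(CN(c1ncnc2c1ncn2C1CCCCO1)C1CC1)NCC(=O)OCc1ccccc1` gives 55.7%
compound 3 `C[C@@H](O)[C@H](NC(=O)CN(c1nc(Cl)nc2[nH]cnc12)C1CC1)C(=O)OCc1ccccc1` gives 21.9%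

Compound 2 stands highest of these three numbers; compound 3 lies nearest to it but clearly below, and compound 1 lies further below still, both gaps beyond the usual scatter. Compound 1 and compound 3, in turn, differ from each other only within that scatter.

The unmeasured compound 4 `CSCC[C@H](NC(=O)CN(c1ncnc2c1ncn2C1CCCCO1)C1CC1)C(=O)OCc1ccccc1` is built from compound 2 by one change: 2-(methylsulfanyl)ethyl in place of hydrogen on a saturated chain carbon bound to an amide-type nitrogen and a carbonyl carbon

Among the compounds with values here, one measured step bears on this: it alters the same place, a saturated chain carbon bound to an amide-type nitrogen and a carbonyl carbon, in the pair sharing the other core. There, a number 3.2 percentage points higher from compound 1 to compound 3 (within the scatter). A side chain at that place thus left the read-out essentially unchanged on one core. Carrying this over, the step from compound 2 to compound 4 is expected to be a number 3.7 percentage points lower from compound 2 to compound 4 (within the scatter), that is, no change beyond the scatter. Compound 4 is therefore estimated at 52%. Within the data shown here, the plausible range estimated for compound 4 runs from an expected lower end of 32% to an expected upper end of 70%, the width reflecting that only one comparable step, on a different core, is available.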

Compound 4, a percentage reported as activity, at one dose (the size of the read-out at that dose, not a potency): 30%
Compound 4: the middle estimate sits 22 percentage points above what was measured, outside the stated range (below it).
By their numbers in this assay, from the lowest: compounds 1, 3 and 4 (each within the scatter of the next, the first and the last beyond it); then compound 2.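

In this assay the saturated chain carbon bound to an amide-type nitrogen and a carbonyl carbon proves sensitive to substitution, which the earlier pair did not reveal: 2-(methylsulfanyl)ethyl in place of hydrogen gives a number 25.7 percentage points lower from compound 2 to compound 4 (beyond the scatter) and so costs a clear part of the effect seen for compound 2. At the same place on the other core, 1-hydroxyethyl gave a number 3.2 percentage points higher from compound 1 to compound 3 (within the scatter) and thus no readable change, so a substituent here does not always leave the read-out alone, although these two steps differ in both the entering group and the core. No measurement available here accounts for the lower number of compound 4.

From the compounds shown here alone, what remains open is whether the entering group or the core decides the size of the step, a question that 1-hydroxyethyl on the core of compound 2 would address directly. Going by these compounds, it is also open whether the sulfur of the chain matters, which a plain butyl chain at this carbon could test, and how an amine or a carboxylic acid at the same place would read.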